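A few compounds are considered here, and "the series" means these few. Any claim that something is new, unique, unknown or untested is made for them only; others in the source may bear on it.

Measured so far in a physicochemical assay for solubility, at pH 7.4; a higher number here means a more soluble compound, a lower number a less soluble compound:
- compound 1 `CN(C)C1(C)CN(c2c(F)cc3c(=O)c(C(=O)O)cn(C4CC4)c3c2F)C1`: 23.6 ug/mL
- compound 2 `CC[C@H]1[C@@H](N)CN1c1c(F)cc2c(=O)c(C(=O)O)cn(C3CC3)c2c1F`: 55.9 ug/mL
- compound 3 `CNC1(C)CN(c2c(F)cc3c(=O)c(C(=O)O)cn(C4CC4)c3c2F)C1`: 0.5 ug/mL

Compound 3 has the lowest number of the three, with compound 1 nearest and compound 2 furthest. The next step leads to compound 4 `CNC1CN(c2c(F)cc3c(=O)c(C(=O)O)cn(C4CC4)c3c2F)C1`, with hydrogen in place of methyl on a saturated ring carbon.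

Going by the values given here, no measured step makes this exact change. The closest is a 47-fold lower number from compound 1 to compound 3 (1.67 log units; beyond the scatter), a large step that also puts hydrogen in place of methyl, but on an amine nitrogen, so its direction need not carry over. The other two steps, a 110-fold lower number from compound 2 to compound 3 (2.05 log units; beyond the scatter) (large) and a 2.4-fold higher number from compound 1 to compound 2 (0.37 log units; beyond the scatter) (modest), exchange the whole group on the aromatic carbon and give only indirect guidance.

Compound 3 stands well apart from the other two, since compound 1 gives 23.6 ug/mL and compound 2 gives 55.9 ug/mL. A move back toward them is therefore expected, though nothing measured fixes its size. The expected change in this assay is a 12-fold higher number from compound 3 to compound 4 (1.08 log units; beyond the scatter), beyond the scatter but uncertain in size. Compound 4 is estimated at 6 ug/mL, with an expected range of 0.8 ug/mL to 40 ug/mL.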

Compound 4, solubility: 1.7 ug/mL
Beside the measured number, compound 4's estimate is 3.5-fold (0.55 log units) above it, within the range that was stated.
By their numbers in this assay, from the lowest: compound 3; then compound 4; then compound 1; then compound 2.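

Going by these compounds alone, this is the only step that isolates the methyl on the saturated ring carbon, two ring bonds from the ring nitrogen, and in this assay hydrogen in place of that methyl gives a modest rise (a 3.4-fold higher number from compound 3 to compound 4 (0.53 log units; beyond the scatter)). Hydrogen in place of methyl on the amine nitrogen goes the opposite way and by more (a 47-fold lower number from compound 1 to compound 3 (1.67 log units; beyond the scatter)), so the same exchange cannot be read across these two places, and the ring-carbon change leaves a large gap to the other compounds (a 33-fold lower number from compound 2 to compound 4 (1.52 log units; beyond the scatter); a 14-fold lower number from compound 1 to compound 4 (1.14 log units; beyond the scatter)). No supporting measurement bears on why the ring-carbon methyl has this effect.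

Still open, from the compounds shown here alone, is whether the step keeps its direction and size with other amines on the azetidine, such as a dimethylamino group in 3-(dimethylamino)azetidin-1-yl, since the ring-carbon change has been read only with the methylamino group. Also open, going by these compounds, is how a propyl chain or a hydroxyl group on that saturated ring carbon would compare with methyl and hydrogen.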